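Fluoro in Place of Hydrogen: Cytotoxicity on Vero Cells

This account rests on a few compounds, and the source may have more. Where it says the series, first, only, none or still open, it means among the compounds named here.

Of the compounds shown here, two of the shared core have been measured in an ADME assay on Vero cells (Chlorocebus sabaeus) for cytotoxicity, read by MTT assay, with a stated time of 72 h; on this read-out lower numbers stand for higher toxicity in this test and higher numbers for lower toxicity in this test. Compound 1 `N/C(=N/NC(CC(=O)c1ccc(-n2ccnc2)cc1)c1cccc(Br)c1)c1ccccn1` carries a bromo group on its pendant ring and gives 51300 nM. Compound 2 `N/C(=N/NC(CC(=O)c1ccc(-n2ccnc2)cc1)c1ccccc1)c1ccccn1` has a plain phenyl in that position and gives 63500 nM, the highest of the two numbers, with compound 1 as its nearest neighbour at a gap that stays within the scatter. Going by the values given here, the one step available, a 1.2-fold higher number from compound 1 to compound 2 (0.09 log units; within the scatter), shows that swapping bromo for hydrogen moved the read-out by an amount no larger than repeat measurements would.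

Compound 3 `N/C(=N/NC(CC(=O)c1ccc(-n2ccnc2)cc1)c1ccccc1F)c1ccccn1` differs from compound 2 by fluoro in place of hydrogen on an aromatic carbon. Among the compounds with values here, since the only comparable step, the removal of a halogen from this ring, stayed within the scatter, a step of similar small size is expected here, a 1.1-fold lower number from compound 2 to compound 3 (0.02 log units; within the scatter), with no clear direction. Compound 3 is therefore estimated at 60000 nM in this assay, expected to fall between 30000 nM and 120000 nM.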

Compound 3, half-maximal cytotoxic concentration: 62100 nM
For compound 3 the middle estimate is 1.0-fold (0.01 log units) below the measured one; the measured number falls inside the stated range.
By their numbers in this assay, from the lowest: compounds 1, 3 and 2 (each within the scatter of the next).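

In this assay the change from phenyl to 2-fluorophenyl gives a 1.0-fold lower number from compound 2 to compound 3 (0.01 log units; within the scatter) and so stays as close to the parent compound as repeat measurements of one sample would. Set against the bromo compound, 2-fluorophenyl in place of 3-bromophenyl gives a 1.2-fold higher number from compound 1 to compound 3 (0.08 log units; within the scatter) and also lies within the scatter, so two different halogens at two different places on this ring now show no readable effect on cell toxicity. Nothing available explains this flat result.

On these data alone, all three compounds carry only hydrogen or a halogen on this ring, so it remains open whether an amine, a carboxylic acid or a methoxy group would leave the read-out just as undisturbed. As far as these compounds go, it also remains open whether changes elsewhere on the shared core would matter more.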